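Swapping trifluoromethoxy for trifluoromethyl in a thiourea

This account rests on a few compounds, and the source may have more. Where it says the series, first, only, none or still open, it means among the compounds named here.

Compound 1 `CC1(C)CCOc2ccc(NC(=S)Nc3ccc(OC(F)(F)F)cc3)cc21` was tested in a functional assay on A2780 cells (Homo sapiens) for inhibition, with a stated time of 72 h (a lower number here means a stronger inhibitor, a higher number a weaker inhibitor), and in this assay compound 1 gives 4300 nM. Two ureas built on a different core were measured alongside it: compound 3 `CC1(C)CC(C)(C)c2cc(NC(=O)Nc3ccc(OC(F)(F)F)cc3)ccc2O1` gives 4560 nM in this assay, and compound 2 `CC1(C)CC(C)(C)c2cc(NC(=O)Nc3ccc(C(F)(F)F)cc3)ccc2O1` gives 3600 nM. The difference between the core of compound 1 and the core of compound 3 is not broken down here. Compound 2 differs from compound 3 in one place: trifluoromethyl in place of trifluoromethoxy on an aromatic carbon This change made a step of a 1.3-fold lower number from compound 3 to compound 2 (0.10 log units; within the scatter). Within the data shown here, the not yet measured compound 4 `CC1(C)CCOc2ccc(NC(=S)Nc3ccc(C(F)(F)F)cc3)cc21` differs from compound 1 by the same change: trifluoromethyl in place of trifluoromethoxy on an aromatic carbon The step from compound 1 to compound 4 in this assay is expected to be small, about a 1.2-fold lower number from compound 1 to compound 4 (0.09 log units; within the scatter), because a 1.3-fold lower number from compound 3 to compound 2 (0.10 log units; within the scatter) barely moved the number in the only measured example of this change. Compound 4 is therefore estimated at 3500 nM in this assay, with a likely range from 1500 nM to 8000 nM.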

Compound 4, half-maximal inhibitory concentration: 5500 nM
Compound 4: middle estimate off by 1.6-fold (0.20 log units), on the low side; low and high end bracket the measured number.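

In this assay, putting trifluoromethyl in place of trifluoromethoxy on the core of compound 1 gives a 1.3-fold higher number from compound 1 to compound 4 (0.11 log units; within the scatter), so the swap again produces only a small step. The change therefore carries over between the two cores as a step too small to read, and the opposite directions of the two steps are no real difference: the same change on two cores in this assay, a 1.3-fold lower number (0.10 log units; within the scatter) from compound 3 to compound 2 and a 1.3-fold higher number (0.11 log units; within the scatter) from compound 1 to compound 4, 1.6-fold (0.21 log units) apart, within the scatter of two such steps. Among these compounds, this does not show that the two groups are interchangeable on other cores, and with only two pairs, which differ in both the core and the urea or thiourea link, it cannot separate the contributions of those two parts.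

On these data alone, all four compounds carry one of these two fluorinated groups at this place on the aromatic ring, so the effect of a different group there, such as an amine, a carboxylic acid or a nitrile, remains open. Also open, as far as these compounds go, is whether any such group would move the number beyond the scatter on either core.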